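Series notes: amine-to-piperidine swap at the six-membered ring

The source may hold more compounds than are shown below. What is called first, only, known or untested is meant among the compounds shown, and "the series" means these compounds.

Three compounds of this set have been run in a functional assay on HeLa cells (Homo sapiens) for inhibition, read by sulforhodamine B assay; on this read-out higher numbers stand for weaker inhibition and lower numbers for stronger inhibition. Compound 1 `O=C1C=C(NC2CCCCC2)C(=O)c2c1nc1n2[C@H]2OC[C@@H](O)[C@H]2OC1` carries a cyclohexylamino group; for compound 1 this assay reports only a limit, > 16000 nM. Compound 2 `COc1ccccc1NC1=CC(=O)c2c(nc3n2[C@H]2OC[C@@H](O)[C@H]2OC3)C1=O` gives 7460 nM in this assay. Compound 3 `O=C1C(NC2CC2)=CC(=O)c2c1nc1n2[C@H]2OC[C@@H](O)[C@H]2OC1` also returns only a limit in this assay, > 16000 nM. Among the compounds with values here, the one measured step, an at least 2.1-fold higher number from compound 2 to compound 3 (0.33 log units; beyond the scatter), moves from a number into the limit region, so compound 1 stands among the weakest values shown, (the limit of > 16000 nM in this assay, at which 2 of the 3 values shown sit).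

The unmeasured compound 4 `O=C1C=C(N2CCCCC2)C(=O)c2c1nc1n2[C@H]2OC[C@@H](O)[C@H]2OC1` differs from compound 1 by piperidin-1-yl in place of cyclohexylamino on a double-bonded ring carbon. Within the data shown here, no measured step of the set changes an amine nitrogen into a ring nitrogen, so nothing here speaks directly to this change; the only comparison, from compound 2 to compound 3, concerns a different substituent. With compound 1 already at the limit, compound 4 is expected to stay there, a step that the limit leaves unreadable from compound 1 to compound 4 in this assay being assumed. The estimate for compound 4 is therefore 20000 nM, within 7000 nM to 60000 nM.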

Compound 4, half-maximal inhibitory concentration: > 16000 nM
Compound 4: only a limit was reported; the forecaster's own chance of this, stated with the estimate: 75%; the middle value is on the limit's open side.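

In this assay compound 4 gives > 16000 nM, a limit, and compound 1 is also held only as a limit, so no step can be read between them. Whether piperidin-1-yl in place of cyclohexylamino changes inhibition at all stays open, with the set gathered at one limit: the limit of > 16000 nM in this assay, at which 3 of the 4 values shown sit.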